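This account rests on a few compounds, and the source may have more. Where it says the series, first, only, none or still open, it means among the compounds named here.

Measured in a functional assay on LoVo cells (Homo sapiens) for inhibition, read by MTT assay, with a stated time of 24 h; on this read-out lower numbers stand for stronger inhibition and higher numbers for weaker inhibition:
Compound 1 `CC1(C)[C@H]2CC[C@]1(C)N(Cc1cn(-c3ccc(F)cc3)nn1)C(=O)C2`: 40 nM
Compound 2 `CC1(C)[C@H]2CC[C@]1(C)N(Cc1cn(-c3ccc(O)cc3)nn1)C(=O)C2`: 410 nM
Compound 3 `CC1(C)[C@H]2CC[C@]1(C)N(Cc1cn(-c3ccccc3)nn1)C(=O)C2`: 50 nM

Compound 3, at 50 nM, sits at the low end of the three numbers and cannot be separated from compound 1. Compound 4 `Cc1ccc(-n2cc(CN3C(=O)C[C@@H]4CC[C@@]3(C)C4(C)C)nn2)cc1` has methyl in place of hydrogen on an aromatic carbon, phenyl to 4-methylphenyl: methyl in place of hydrogen on an aromatic carbon. Two measured changes on that same carbon bear on it. Fluoro and hydrogen differ little, a 1.3-fold higher number from compound 1 to compound 3 (0.10 log units; within the scatter), whereas hydroxy costs much more, an 8.2-fold lower number from compound 2 to compound 3 (0.91 log units; beyond the scatter). Among the compounds with values here, no methyl compound has been measured, so the sensitivity of this carbon leaves some risk. The expected change is small, with no shift beyond the scatter in this assay, and the estimated step is a 1.2-fold higher number from compound 3 to compound 4 (0.08 log units; within the scatter). For compound 4 the estimate is 60 nM, with an expected range of 20 nM to 220 nM.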

Compound 4, half-maximal inhibitory concentration: 50 nM
Compound 4: middle estimate off by 1.2-fold (0.08 log units), on the high side; the range from low to high includes it.
By their numbers in this assay, from the lowest: compounds 1, 3 and 4 (each within the scatter of the next); then compound 2.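

In (this assay), this aromatic carbon accepts a methyl group with no shift against hydrogen (no change at the digits printed from compound 3 to compound 4 (within the scatter)) or against fluoro (a 1.3-fold higher number from compound 1 to compound 4 (0.10 log units; within the scatter)). Among the four groups shown, hydroxy alone stands apart, as replacing it with methyl gives (an 8.2-fold lower number from compound 2 to compound 4 (0.91 log units; beyond the scatter)). No available evidence explains this difference.

Going by these compounds, whether methoxy, an amine or a carboxylic acid on this carbon would track hydroxy or the other three groups remains open. So does whether a longer chain, such as propyl, would be accepted as methyl is.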